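The compounds below may be only part of what the source reports. "The series", "measured", "known", "first", "only" and "open" are said of these compounds alone.

In a functional assay on HT-29 cells (Homo sapiens) for inhibition, read by MTT assay, with a stated time of 72 h (a higher number here means a weaker inhibitor of growth, a lower number a stronger inhibitor of growth), compound 3 `COc1ccc(CNC(=O)/C(C#N)=C/c2ccc(C)o2)cc1` gives 92000 nM, the lowest of the two numbers obtained; compound 1 `N#C/C(=C\c1c(F)c(F)c(F)c(F)c1F)C(=O)c1ccc[nH]1` gives 224000 nM, and the gap from compound 3 to compound 1 is beyond the scatter. Compound 2 `COc1ccc(CNC(=O)/C(C#N)=C/c2ccc[nH]2)cc1` reaches in this assay only a limit, > 50000 nM, and this is the limit of > 50000 nM in this assay, at which 1 of the 3 values shown sits. Because of that limit the step that the limit leaves unreadable from compound 2 to compound 3 cannot be read. Compound 4 `COc1ccc(CNC(=O)/C(C#N)=C/c2ccc(Br)o2)cc1` carries bromo in place of methyl on an aromatic carbon, a bromo in place of methyl on an aromatic carbon of a five-membered aromatic ring with 1 oxygen, next to the ring oxygen. Among the measured compounds shown here, no measured step touches a group at this carbon, so the series gives no direction; the expected step of a 1.1-fold lower number from compound 3 to compound 4 (0.03 log units; within the scatter) is none beyond the scatter. Compound 4 is estimated in this assay at 85000 nM, with a range from 30000 nM to 250000 nM.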

Compound 4, concentration for 50% growth inhibition: 10000 nM
Beside the measured number, compound 4's estimate is 8.5-fold (0.93 log units) above it, and the stated range ends above it.
By their numbers in this assay, from the lowest: compound 4; then compound 3; then compound 1.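

In this assay, among the compounds shown here, the group on the aromatic carbon next to the ring oxygen matters: bromo in place of methyl gives a 9.2-fold lower number from compound 3 to compound 4 (0.96 log units; beyond the scatter), the first readable change at this carbon. The 5-bromofuran-2-yl group in place of 1H-pyrrol-2-yl gives an at least 5.0-fold lower number from compound 2 to compound 4 (0.69 log units; beyond the scatter). That step rests on the limit reached by compound 2: the limit of > 50000 nM in this assay, at which 1 of the 4 values shown sits.

Only methyl and bromo can be compared at this carbon, so no trend across substituents can be drawn. On these data alone, how chloro, methoxy or an amine would read there remains open.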